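A few compounds are considered here, and "the series" means these few. Any claim that something is new, unique, unknown or untested is made for them only; others in the source may bear on it.

Compound 1, `C[C@@H]1CC(c2cnc3c(C#N)nn([C@H](C)c4ccc(Cl)cc4Cl)c3n2)=CC[C@@H]1N1CCC[C@H]1C(C)(C)O`, is the weaker of the two compounds with a number in an assay on CCRF-CEM cells for antagonist activity at C-C chemokine receptor type 4 (Homo sapiens), read by CellTiter-Glo, with stated times of 30 min and 60 min, in the presence of a further agent that is not named here; a lower number here means a stronger inhibitor, a higher number a weaker inhibitor: compound 1 gives 1200 nM, whereas compound 2, `Cc1nn([C@H](C)c2ccc(Cl)cc2Cl)c2nc(N3CC[C@H](N4CCC[C@H]4CCC(N)=O)[C@H](C)C3)cnc12`, gives 355 nM, a gap beyond the usual scatter. Compound 3, `Cc1nn([C@H](C)c2ccc(Cl)cc2Cl)c2nc(N3CC[C@H](N4CCC[C@H]4C(=O)O)[C@H](C)C3)cnc12`, has "not determined" (no result reported) in this assay. Compound 4, `C[C@@H]1CC(c2cnc3c(C#N)nn([C@H](C)c4ccc(Cl)cc4Cl)c3n2)=CC[C@@H]1N1CCC[C@H]1C(N)=O`, differs from compound 1 by one change: carbamoyl in place of 1-hydroxy-1-methylethyl on a saturated ring carbon, so that a carbamoyl replaces the 1-hydroxy-1-methylethyl group on a saturated ring carbon. Among the compounds with values here, no measured pair shows this change, so its effect is uncertain; a step of modest size is expected, most likely toward a somewhat lower number, with a 1.5-fold lower number from compound 1 to compound 4 (0.18 log units; within the scatter) as the estimated step. For compound 4 in this assay the estimate is 800 nM, with a range from 250 nM to 2600 nM.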

Compound 4, half-maximal inhibitory concentration: 1380 nM
The estimate for compound 4 lay 1.7-fold (0.24 log units) below the measured number; low and high end bracket the measured number.
By their numbers in this assay, from the lowest: compound 2; then compounds 1 and 4 (each within the scatter of the next).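

In this assay the exchange gives a 1.2-fold higher number from compound 1 to compound 4 (0.06 log units; within the scatter) and so leaves the number within the scatter. Within the data shown here, this pair is the first to isolate this saturated ring carbon, next to the ring nitrogen, and here carbamoyl and 1-hydroxy-1-methylethyl cannot be told apart. No measurement shown here explains this result.

Going by these compounds, whether an amine or a methyl ether at this position would shift the number beyond the scatter remains open. So does whether the same exchange would behave alike on the core of compound 2.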